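The source may report more compounds than this note shows. Statements on the series, on what has been measured and on what is new or still open speak of the compounds shown alone.

Measured compounds in a functional assay on the whole organism (B cells) with Mus musculus as the target; a lower number here means a smaller maximal response, a higher number a larger maximal response:
Compound 1 `Nc1nc(O)c2c(n1)n(C1OC(CO)[C@@H](O)[C@H]1O)c(=O)n2CC(O)CSc1ccccc1` gives 12%.
Compound 2 `CCOC(=O)Cn1c(=O)n(C2OC(CO)[C@@H](O)[C@H]2O)c2nc(N)nc(O)c21` gives 86%.
Compound 3 `C=CCn1c(=O)n(CCCC)c2nc(N)nc(O)c21` gives 77%.

Compound 2 stands highest of the three in this assay; compound 3 lies within the scatter of it, and compound 1 lies far below it. Compound 4 `N#Cc1ccc(Cn2c(=O)n(C3OC(CO)[C@@H](O)[C@H]3O)c3nc(N)nc(O)c32)cc1` differs from compound 2 at one place: 4-cyanophenyl in place of ethoxycarbonyl on a saturated chain carbon bound to an aromatic nitrogen. For the measured compounds named here, only one measured step touches this place, a number 74 percentage points higher from compound 1 to compound 2 (beyond the scatter), and it shows that the group on this saturated chain carbon can swing the maximal response widely. Since a phenyl ring returns in compound 4, as in compound 1, a fall is considered likely, estimated as a number 36 percentage points lower from compound 2 to compound 4 (beyond the scatter). Compound 4 is therefore expected to give 50%, with a wide range from 15% to 90%.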

Compound 4, largest response reached (reported as maximal response), in percent of the reference or control that the assay uses: 50%
Compound 4: the middle estimate sits on the measured number at the digits printed; the measured number falls inside the stated range.
By their numbers in this assay, from the lowest: compound 1; then compound 4; then compounds 3 and 2 (each within the scatter of the next).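

In this assay, 4-cyanophenyl in place of ethoxycarbonyl gives a number 36 percentage points lower from compound 2 to compound 4 (beyond the scatter) and in place of 1-hydroxy-2-(phenylsulfanyl)ethyl gives a number 38 percentage points higher from compound 1 to compound 4 (beyond the scatter) on this saturated chain carbon bound to an aromatic nitrogen. This position therefore allows an intermediate maximal response as well as the high and low levels seen earlier, and an aromatic ring here need not bring the response down to the level of compound 1. No measurement available here explains these steps. Going by these compounds, what an unsubstituted benzyl group or a carboxylic acid on this chain carbon would give remains open, as does whether the nitrile or the ring sets the level of compound 4.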